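Aryl replacements on a fused lactam core

The compounds below may be only part of what the source reports. "The series", "measured", "known", "first", "only" and "open" are said of these compounds alone.

Measured compounds:
Compound 1 `C[C@@H](O[C@H]1CN2C(=O)C=C(c3ccncc3)CC2[C@@H]1c1ccc(F)cc1)c1cc(C(F)(F)F)cc(C(F)(F)F)c1`, compound 2 `C[C@@H](O[C@H]1CN2C(=O)C=C(c3cc[n+]([O-])cc3)CC2[C@@H]1c1ccc(F)cc1)c1cc(C(F)(F)F)cc(C(F)(F)F)c1`, compound 3 `C[C@@H](O[C@H]1CN2C(=O)C=C(c3cc[nH]c(=O)c3)CC2[C@@H]1c1ccc(F)cc1)c1cc(C(F)(F)F)cc(C(F)(F)F)c1`.

Three analogues share the core of compound 1 and differ only in the aromatic group on a double-bonded ring carbon. In an assay on CHO cells for displacement of a labelled ligand from Substance-P receptor (Homo sapiens) (on this read-out higher numbers stand for weaker inhibition and lower numbers for stronger inhibition), compound 1 gives 0.14 nM. In this assay compound 2 gives 0.1 nM, and compound 3 gives 0.27 nM. Among the three numbers compound 3 gives the highest, but its distance to compound 1 is within the scatter, a 1.9-fold higher number from compound 1 to compound 3 (0.29 log units; within the scatter), while the distance from compound 2 is a little larger, a 2.7-fold higher number from compound 2 to compound 3 (0.43 log units; beyond the scatter). Among the measured compounds shown here, the first exchange at this position, a 1.4-fold lower number from compound 1 to compound 2 (0.15 log units; within the scatter), is also within the scatter.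

Compound 4 `C[C@@H](O[C@H]1CN2C(=O)C=C(c3cnn(C)c3)CC2[C@@H]1c1ccc(F)cc1)c1cc(C(F)(F)F)cc(C(F)(F)F)c1` is the next member. Compared with compound 3 it carries a group of 6 heavy atoms (4 carbon, 2 nitrogen; one five-membered aromatic ring with 2 hetero atoms) in place of a group of 7 heavy atoms (5 carbon, 1 nitrogen, 1 oxygen; one six-membered aromatic ring with 1 hetero atom), on a double-bonded ring carbon. The two measured exchanges at this position moved the number only modestly, and all three aromatic groups so far have kept the number low, so the five-membered ring is expected to do the same. The expected step is a 1.4-fold lower number from compound 3 to compound 4 (0.13 log units; within the scatter), essentially no change beyond the scatter. For compound 4 an estimate of 0.2 nM is given, within a range of 0.07 nM to 0.6 nM.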

Compound 4, half-maximal inhibitory concentration: 0.13 nM
Beside the measured number, compound 4's estimate is 1.5-fold (0.19 log units) above it; the measured number falls inside the stated range.
By their numbers in this assay, from the lowest: compounds 2, 4, 1 and 3 (each within the scatter of the next, the first and the last beyond it).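

Among the compounds shown here, the 1-methyl-1H-pyrazol-4-yl group shows that this double-bonded ring carbon can carry a five-membered aromatic ring with 2 hetero atoms, where the earlier compounds all held six-membered aromatic rings with 1 hetero atom, and in this assay the exchange for pyridin-4-yl stays within the scatter (a 1.1-fold lower number from compound 1 to compound 4 (0.03 log units; within the scatter)). A second comparison also stays within the scatter (a 1.3-fold higher number from compound 2 to compound 4 (0.11 log units; within the scatter)), while the third is modest but beyond it (a 2.1-fold lower number from compound 3 to compound 4 (0.32 log units; beyond the scatter)), and in that step a group counted with 1 hydrogen-bond donor gives way to one with 0, which leaves compound 3 as the only one of the four set apart beyond the scatter from two others. Nothing available here explains these steps.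

A single exchange cannot tell whether the hydrogen-bond donor count has anything to do with the step, and a pyrazol-4-yl group without its methyl would be needed to separate the ring from that substituent. As far as these compounds go, it also remains open whether this ring carbon keeps such low numbers with a non-aromatic group, such as a morpholine, a simple amine or a carboxylic acid.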